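Carbamate ester variation on the shared core

This account rests on a few compounds, and the source may have more. Where it says the series, first, only, none or still open, it means among the compounds named here.

Three carbamates on the shared core have numbers in a functional assay on isolated protein for inhibition of Glucose-dependent insulinotropic receptor (Homo sapiens), read by HTRF and cAMP accumulation; a higher number here means that more compound is needed for the effect, a lower number that less compound is needed. Compound 1 `Cc1nc(S(C)(=O)=O)ccc1Oc1ncnc(OC2CCN(C(=O)OC(C)C)CC2)c1F` gives 21 nM. Compound 2 `Cc1nc(S(C)(=O)=O)ccc1Oc1ncnc(OC2CCN(C(=O)OC3CCC3)CC2)c1F` gives 13.6 nM. Compound 3 `CCC1(OC(=O)N2CCC(Oc3ncnc(Oc4ccc(S(C)(=O)=O)nc4C)c3F)CC2)CC1` gives 22 nM, the highest of the three numbers, though its steps to the others are within the scatter: a 1.0-fold higher number from compound 1 to compound 3 (0.02 log units; within the scatter) and a 1.6-fold higher number from compound 2 to compound 3 (0.21 log units; within the scatter).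

Compound 4 `Cc1nc(S(C)(=O)=O)ccc1Oc1ncnc(OC2CCN(C(=O)OC3(C(F)(F)F)COC3)CC2)c1F` has not been measured in this assay. It differs from compound 3 in one place: 3-(trifluoromethyl)oxetan-3-yl in place of 1-ethylcyclopropyl on an oxygen next to a carbonyl group.

For the measured compounds named here, every measured step so far changes the same group on the oxygen next to the carbonyl group, and none left the scatter: a 1.5-fold lower number from compound 1 to compound 2 (0.19 log units; within the scatter), a 1.0-fold higher number from compound 1 to compound 3 (0.02 log units; within the scatter), a 1.6-fold higher number from compound 2 to compound 3 (0.21 log units; within the scatter). Going by the values given here, no measured step introduces an oxygen-containing ring or fluorine at this place, so the change to compound 4 goes further than anything covered. On the measured steps alone no step beyond the scatter is expected, with the range widened for the uncovered part of the change.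

For compound 4 the expected value in this assay is 25 nM, within 8 nM to 75 nM, an expected step of a 1.1-fold higher number from compound 3 to compound 4 (0.06 log units; within the scatter).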

Compound 4, half-maximal effective concentration: 29.3 nM
For compound 4 the middle estimate is 1.2-fold (0.07 log units) below the measured one; the range from low to high includes it.
By their numbers in this assay, from the lowest: compounds 2, 1, 3 and 4 (each within the scatter of the next, the first and the last beyond it).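

In this assay, for the compounds shown here, the place on an oxygen next to a carbonyl group takes 3-(trifluoromethyl)oxetan-3-yl, the first group here with a hetero atom in its ring and with fluorine, and both a 1.3-fold higher number from compound 3 to compound 4 (0.12 log units; within the scatter) and a 1.4-fold higher number from compound 1 to compound 4 (0.14 log units; within the scatter) stay small. Going by these compounds alone, only the change from cyclobutyl leaves the scatter, in a 2.2-fold higher number from compound 2 to compound 4 (0.33 log units; beyond the scatter) as the first such step at this place, and it is a modest one. Nothing measured here accounts for these steps.

The four-membered ring with its oxygen and the trifluoromethyl enter together, and the share of each in these steps stays unresolved. As far as these compounds go, how an amine, a carboxylic acid or a longer chain on this oxygen would read in this assay also stays open.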